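The source may hold more compounds than are shown below. What is called first, only, known or untested is meant among the compounds shown, and "the series" means these compounds.

Measured so far in a functional assay on MDA-MB-231 cells (Homo sapiens) for antiproliferative activity, read by sulforhodamine B assay, with a stated time of 48 h; on this read-out lower numbers stand for stronger inhibition and higher numbers for weaker inhibition:
- compound 1 `COc1cc(OC)c2sc(-c3ccc(N/C=C\C(=O)c4ccc(OC)c(O)c4)cc3)nc2c1` gives 7610 nM
- compound 2 `COc1cc(OC)c2sc(-c3ccc(N/C=C\C(=O)c4cc(OC)c(OC)c(OC)c4)cc3)nc2c1` gives 15800 nM

Going by the values given here, of these two numbers, the one for compound 2 is the higher, so compound 2 is the weaker inhibitor of the pair. Among the compounds with values here, its only neighbour is compound 1. The step of a 2.1-fold higher number from compound 1 to compound 2 (0.32 log units; beyond the scatter) is modest but beyond the usual scatter. Compound 1 carries 3-hydroxy-4-methoxyphenyl on its carbonyl, and compound 2 carries 3,4,5-trimethoxyphenyl there.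

Compound 3 `COc1cc(C(=O)/C=C\Nc2ccc(-c3nc4cc(OC)c(OC)c(OC)c4s3)cc2)cc(OC)c1OC` keeps that 3,4,5-trimethoxyphenyl and changes the shared core instead. The difference is methoxy in place of hydrogen on an aromatic carbon, ortho to two methoxy groups. Within the data shown here, no measured step touches this place, since the single step available, the one leading to compound 2, lies elsewhere in the molecule. With nothing to set a direction, no step beyond the scatter is expected in this assay. The estimated step, a 1.1-fold lower number from compound 2 to compound 3 (0.02 log units; within the scatter), is therefore expected to be small. For compound 3 the expected value is 15000 nM, with an estimated range of 5500 nM to 40000 nM.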

Compound 3, half-maximal inhibitory concentration: 16500 nM
Beside the measured number, compound 3's estimate is 1.1-fold (0.04 log units) below it; measured number inside the range.
By their numbers in this assay, from the lowest: compound 1; then compounds 2 and 3 (each within the scatter of the next).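

In this assay, putting methoxy in place of hydrogen on this aromatic carbon of the shared core, ortho to two methoxy groups, gives a 1.0-fold higher number from compound 2 to compound 3 (0.02 log units; within the scatter), so on this read-out the added group cannot be told apart from hydrogen. Going by these compounds alone, the earlier step concerned only the group on the carbonyl, so this is the first reading at this position, and it shows that, with 3,4,5-trimethoxyphenyl on the carbonyl, the position accepts a methoxy group with no change beyond the scatter. No supporting evidence bears on this result, so the flat step stands as an observation without an explanation.

On these data alone, this reading comes from a single group on the carbonyl, so it remains open whether methoxy at this carbon would have the same small effect alongside the 3-hydroxy-4-methoxyphenyl of compound 1. As far as these compounds go, only hydrogen and methoxy appear at this carbon here, so it is also open whether a different group there, such as an amine, a carboxylic acid or a longer alkoxy chain, would shift the number beyond the scatter.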